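From 2-chlorophenyl to 4-hydroxyphenyl on a shared core

A few compounds are considered here, and "the series" means these few. Any claim that something is new, unique, unknown or untested is made for them only; others in the source may bear on it.

In a functional assay on HepG2 cells (Homo sapiens) for antiproliferative activity, read by MTT assay, with a stated time of 24 h (on this read-out lower numbers stand for stronger inhibition and higher numbers for weaker inhibition), compound 1 (`COc1ccc(C(=O)/C=C/c2ccsc2)c2c1C=CC(C)(C)O2`) gives > 10000 nM, which is a limit and not a number. Compound 2 (`COc1ccc(C(=O)/C=C/c2ccccc2Cl)c2c1C=CC(C)(C)O2`) is also reported only as a limit, at > 10000 nM. Compound 2 therefore has no exact position in this assay.

Compound 3 (`COc1ccc(C(=O)/C=C/c2ccc(O)cc2)c2c1C=CC(C)(C)O2`) differs from compound 2 in one place: 4-hydroxyphenyl in place of 2-chlorophenyl on a double-bonded chain carbon bound to a double-bonded chain carbon. The 4-hydroxyphenyl group stands in place of 2-chlorophenyl, on a double-bonded chain carbon bound to a double-bonded chain carbon.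

For the measured compounds named here, only one measured step bears on this change: a step that the two limits leave unreadable from compound 1 to compound 2. It has no readable size, and the whole evidence is the limit of > 10000 nM in this assay, at which 2 of the 2 values shown sit. Going by the values given here, no measured step therefore gives a size or direction to carry over to the new group. Compound 2 offers no number to step from because > 10000 nM is a limit.

The expectation is therefore no change beyond the scatter in this assay, with a report at the limit the likeliest outcome. The estimated size is a step that the limit leaves unreadable from compound 2 to compound 3. Compound 3 is expected at about 12000 nM, within an estimated range of 3000 nM to 40000 nM.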

Compound 3, half-maximal inhibitory concentration: > 10000 nM
Compound 3 ended at the assay's limit; the forecaster's own chance of this, stated with the estimate: 70%; the middle value lies beyond the limit too.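

No new step can be read among compound 1, compound 2 and compound 3 in this assay because each is reported only as a limit: the limit of > 10000 nM in this assay, at which 3 of the 3 values shown sit.

The compounds shown leave open how thiophen-3-yl, 2-chlorophenyl and 4-hydroxyphenyl rank against one another, and whether any group at this place on the shared core gives a value inside the limit.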